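From a Limit to a Number: Compound 3 to Compound 4

This account rests on a few compounds, and the source may have more. Where it says the series, first, only, none or still open, it means among the compounds named here.

Three compounds have been measured in an assay on CHO cells for displacement of a labelled ligand from adenosine receptor A3 (Homo sapiens), read by scintillation counting, with a stated time of 60 min; a lower number here means a stronger inhibitor, a higher number a weaker inhibitor:
compound 1, `COc1cccc(CCC(=O)Nc2nc3ccccc3c(=O)s2)c1`, gives 173 nM
compound 2, `COc1cccc(CCCC(=O)Nc2nc3ccccc3c(=O)s2)c1`, gives 382 nM
compound 3, `O=C(CCc1ccccc1Br)Nc1nc2ccccc2c(=O)s1`, gives > 1000 nM

For compound 3 the result is only a limit of the assay, not a number, as the limit of > 1000 nM in this assay, at which 1 of the 3 values shown sits, records. Compound 3 therefore stands at the weak end of what has been measured, with no number of its own. The step of an at least 5.7-fold higher number from compound 1 to compound 3 (0.76 log units; beyond the scatter) shows that moving from the 3-methoxyphenyl of compound 1 to the 2-bromophenyl of compound 3 cost at least a modest amount of binding.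

Compound 4, `O=C(CCCc1cccc(Cl)c1)Nc1nc2ccccc2c(=O)s1`, has not been measured. Its change from compound 3 is 3-chlorobenzyl in place of 2-bromophenyl on a saturated chain carbon, two bonds along the chain from a carbonyl carbon. This undoes the 2-bromophenyl that accompanied the loss in the step from compound 1 to compound 3, and the 3-chlorobenzyl it brings in gives compound 4 the same chain length as compound 2, which carries a 3-methoxyphenyl on that longer chain. Because the step of an at least 5.7-fold higher number from compound 1 to compound 3 (0.76 log units; beyond the scatter) ran toward weaker binding, reversing the 2-bromophenyl is expected to run the other way, and the values of compound 1 and compound 2 suggest where a meta-substituted aryl on this core lands. The expected step is an at least 2.2-fold lower number from compound 3 to compound 4 (0.34 log units; beyond the scatter). Compound 4 is therefore estimated at 450 nM, within a range from 150 nM to 1500 nM.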

Compound 4, inhibition constant: > 1000 nM
Compound 4: a limit, no number; the forecaster's own chance of this, stated with the estimate: 20%; middle value at least 2.2-fold (0.34 log units) from the limit.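

Compound 4 gives only a limit of the assay, not a number, and compound 3 sits at the same limit: the limit of > 1000 nM in this assay, at which 2 of the 4 values shown sit. The step between these two compounds cannot be read, but replacing the 2-bromophenyl with 3-chlorobenzyl did not yield a number, so that group alone does not account for the loss seen with compound 3. On the same chain, chloro in place of methoxy on an aromatic carbon gives an at least 2.6-fold higher number from compound 2 to compound 4 (0.41 log units; beyond the scatter), and the change from the shorter methoxy compound gives an at least 5.7-fold higher number from compound 1 to compound 4 (0.76 log units; beyond the scatter), so only the two methoxy compounds give numbers here.

On these data alone, whether methoxy is specifically needed remains open, and an ethoxy or a hydroxyl group at that ring position would test this. As far as these compounds go, the true values of compound 3 and compound 4 also remain unknown, so these two cannot be ranked.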